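This account rests on a few compounds, and the source may have more. Where it says the series, first, only, none or still open, it means among the compounds named here.

Compound 1 `C=C[C@@H]1OC(c2ccc(Cl)cc2)=N[C@H]1S` pairs a chloro on an aromatic carbon with a sulfanyl on the saturated ring carbon of the shared core. In an assay on isolated protein for inhibition of matrix metalloproteinase-9 (Homo sapiens) (a lower number here means a stronger inhibitor, a higher number a weaker inhibitor), compound 1 gives only a limit, > 100000 nM. Compound 2 `C=C[C@@H]1OC(c2ccc(Br)cc2)=N[C@H]1S` carries bromo in place of chloro on an aromatic carbon; in this assay compound 2 likewise reaches only a limit, > 100000 nM. The step that the two limits leave unreadable from compound 1 to compound 2 therefore cannot be read in size. Compound 3 `C=C[C@@H]1OC(CCCCC)=N[C@H]1CO` bears a pentyl chain and a hydroxymethyl on the saturated ring carbon; in this assay compound 3 also gives a limit, > 2000000 nM. Compound 1 thus stands at the limit of > 100000 nM in this assay, at which 2 of the 3 values shown sit. The remaining value sits at the limit of > 2000000 nM in this assay, at which 1 of the 3 values shown sits.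

Compound 4 `C=C[C@@H]1OC(c2ccc(Cl)cc2)=N[C@H]1CO` differs from compound 1 by hydroxymethyl in place of sulfanyl on a saturated ring carbon. Within the data shown here, no measured step touches this position, so none bears on it directly; the one measured step available is unreadable, and the only other hydroxymethyl example, compound 3, sits at a limit. Compound 4 is therefore expected to show no step beyond the scatter in this assay, a step that the limit leaves unreadable from compound 1 to compound 4, and most likely to remain at a limit. The estimate for compound 4 is 500000 nM, within 50000 nM to 5000000 nM.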

Compound 4, inhibition constant: 33000 nM
For compound 4 the middle estimate is 15-fold (1.18 log units) above the measured one; measured number below the stated range.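

In this assay, hydroxymethyl in place of sulfanyl on the saturated ring carbon gives an at least 3.0-fold lower number from compound 1 to compound 4 (0.48 log units; beyond the scatter), a change that adds one heavy atom and leaves the count of one hydrogen-bond donor and one hydrogen-bond acceptor as it was. This is the first sign that this position can shift the read-out, and compound 4 holds the only number among the compounds shown, while compound 1 and compound 2 stay at a shared limit: the limit of > 100000 nM in this assay, at which 2 of the 4 values shown sit. Hydroxymethyl alone does not bring a number, however, as compound 3, which carries it with a pentyl chain in place of the chloro-bearing aromatic group, gives only a limit, > 2000000 nM.

Going by these compounds, the step from compound 1 to compound 2 cannot be read, so it remains open whether bromo in place of chloro would matter on the hydroxymethyl compound, and the true size of the step to compound 4 is also unknown, as only its lower bound is given. The compounds shown also leave open how an amine, a carboxylic acid or a longer chain ending in a hydroxyl would fare on this saturated ring carbon.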